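A dichlorophenyl swap on a shared core

The compounds below may be only part of what the source reports. "The series", "measured", "known", "first", "only" and "open" are said of these compounds alone.

Measured in a functional assay on B16-F10 cells (Mus musculus) for cytotoxicity; on this read-out lower numbers stand for stronger inhibition and higher numbers for weaker inhibition:
Compound 1 `O=c1oc2ccccc2c2nc3c(ccc4cc[nH]c43)c(-c3cccc4ccccc34)c12`: 70700 nM
Compound 2 `O=c1oc2ccccc2c2nc3c(ccc4cc[nH]c43)c(-c3ccc([N+](=O)[O-])cc3)c12`: 70700 nM

Compound 2, at 70700 nM, stands level with compound 1, so neither can be ranked above the other. The next compound, compound 3 `O=c1oc2ccccc2c2nc3c(ccc4cc[nH]c43)c(-c3ccc(Cl)cc3Cl)c12`, keeps the shared core and carries 2,4-dichlorophenyl in place of 4-nitrophenyl on an aromatic carbon, opposite the ring nitrogen (2,4-dichlorophenyl in place of 4-nitrophenyl on an aromatic carbon). Among the compounds with values here, only one measured step bears on this change, since it falls on the same aromatic carbon: no change at the digits printed from compound 1 to compound 2 (within the scatter). Within the data shown here, that single exchange of 4-nitrophenyl for naphthalen-1-yl is thin evidence, and no measured compound carries chlorine. The expected step is therefore small, with none anticipated beyond the scatter in this assay, and the estimate is a 1.3-fold lower number from compound 2 to compound 3 (0.11 log units; within the scatter). For compound 3 the estimated value is 55000 nM, with an expected range of 18000 nM to 85000 nM.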

Compound 3, half-maximal inhibitory concentration: 70700 nM
Compound 3: middle estimate off by 1.3-fold (0.11 log units), on the low side, and the stated range covers the measured number.
By their numbers in this assay, from the lowest: compounds 1, 2 and 3 (each within the scatter of the next).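

In this assay, putting 2,4-dichlorophenyl on this aromatic carbon, opposite the ring nitrogen, extends the flat picture to a third aromatic group and to the first one carrying chlorine, both against 4-nitrophenyl (no change at the digits printed from compound 2 to compound 3 (within the scatter)) and against naphthalen-1-yl (no change at the digits printed from compound 1 to compound 3 (within the scatter)). The read-out therefore separates none of these three groups, although they differ in their atoms and in the number of rings they bring to this carbon, and that statement holds for these compounds only. Nothing among the data offers an explanation for this sameness.

From the compounds shown here alone, it remains open whether a group of another kind on this carbon, such as an amine, a carboxylic acid or a longer alkyl chain, would move the number beyond the scatter. Going by these compounds, it also remains open whether a change elsewhere on the shared core would do so.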